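Methyl steps in a small antiproliferative series

The source may hold more compounds than are shown below. What is called first, only, known or untested is meant among the compounds shown, and "the series" means these compounds.

Measured so far:
compound 1 `Cc1ccc2[nH]c(-c3c(-c4ccc(F)cc4)nc4sc(C)nn34)nc2c1` — 7700 nM
compound 2 `Cc1nn2c(-c3nc4ccccc4[nH]3)c(-c3ccc(F)cc3)nc2s1` — 22200 nM
compound 3 `Cc1ccc(-c2nc3sc(C)nn3c2-c2nc3cc(C)ccc3[nH]2)cc1` — 6100 nM

All three were run in a functional assay on A-375 cells (Homo sapiens) for antiproliferative activity, read by MTT assay; on this read-out higher numbers stand for weaker inhibition and lower numbers for stronger inhibition. Compound 2 gives 22200 nM and compound 1 gives 7700 nM; the change between them is methyl in place of hydrogen on an aromatic carbon and the step is a 2.9-fold lower number from compound 2 to compound 1 (0.46 log units; beyond the scatter). Compound 3 differs from compound 1 by methyl in place of fluoro on an aromatic carbon, a step of a 1.3-fold lower number from compound 1 to compound 3 (0.10 log units; within the scatter), so compounds 1 and 3 are not ordered against each other by these numbers. How the core of compound 3 differs from the core of compound 2 is not broken down here; compound 2 gives 22200 nM and compound 3 gives 6100 nM in this assay.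

Compound 4 `Cc1ccc(-c2nc3sc(C)nn3c2-c2nc3c(C)c(C)ccc3[nH]2)cc1` is not yet measured. It differs from compound 3 by methyl in place of hydrogen on an aromatic carbon. Within the data shown here, this is the same kind of change as the one from compound 2 to compound 1, not the same: there the methyl entered meta to a fused ring and para to a fused ring, here it enters ortho to a fused ring, ortho to a methyl group and meta to a fused ring. Among the measured compounds shown here, the estimated step of a 1.7-fold lower number from compound 3 to compound 4 (0.24 log units; within the scatter) is taken as somewhat smaller than the earlier one because a 2.9-fold lower number from compound 2 to compound 1 (0.46 log units; beyond the scatter) stands at a different place and is the only prior instance of this kind of change. Compound 4 is expected to give 3500 nM, with a likely range from 1500 nM to 9000 nM.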

Compound 4, half-maximal inhibitory concentration: 11400 nM
The estimate for compound 4 lay 3.3-fold (0.51 log units) below the measured number, and the stated range ends below it.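

In this assay, methyl in place of hydrogen on an aromatic carbon gives a 1.9-fold higher number from compound 3 to compound 4 (0.27 log units; within the scatter), so this pair is not ordered by these numbers, and the change does not repeat the size it had on the other core: the same change on two cores in this assay, a 2.9-fold lower number (0.46 log units; beyond the scatter) from compound 2 to compound 1 and a 1.9-fold higher number (0.27 log units; within the scatter) from compound 3 to compound 4, 5.4-fold (0.73 log units) apart, beyond the scatter of two such steps

For this series, the step from compound 2 to compound 1 therefore cannot serve as a transferable value for this methyl change, and two instances are too few to set a rule for it. Among these compounds, what the comparison does not show is the source of the gap: the two instances differ both in the rest of the molecule and in where the methyl enters, with the methyl of compound 4 ortho to a methyl group, and no pair here holds one of these fixed while varying the other.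

Still open, from the compounds shown here alone, is whether the methyl of compound 4 would give the same result on the core of compound 2, which would separate place from core. Also open, going by these compounds, is how an amine, a carboxylic acid or a longer chain would behave at the same aromatic carbon, as every change on that ring here is a methyl.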